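The compounds below may be only part of what the source reports. "The series", "measured", "known", "first", "only" and "open" are said of these compounds alone.

Of the compounds shown here, two sharing one core have been tested in a functional assay on MGC-803 cells (Homo sapiens) for antiproliferative activity, read by MTT assay, with a stated time of 72 h; on this read-out lower numbers stand for stronger inhibition and higher numbers for weaker inhibition. Compound 1, `CCCSc1nc(N/N=C/c2ccccc2Cl)c2nnn(Cc3ccccc3)c2n1`, gives 10900 nM in this assay. Compound 2, `CCCSc1nc(N/N=C/c2cc(OC)c(OC)c(OC)c2)c2nnn(Cc3ccccc3)c2n1`, gives 9410 nM in this assay. Compound 1 holds the higher of the two numbers, but its gap to compound 2 lies within the usual scatter of repeated measurements, so the two cannot be told apart. The next compound is compound 3, `CCCSc1nc(N/N=C/c2ccccc2)c2nnn(Cc3ccccc3)c2n1`, not yet measured. It differs from compound 1 in one place: hydrogen in place of chloro on an aromatic carbon. For the measured compounds named here, no pair of measured compounds shows what this change does here, so the expectation rests on the two numbers alone, which sit close together. The step of a 1.2-fold higher number from compound 1 to compound 3 (0.08 log units; within the scatter) is therefore expected to be small, leaning if anything toward a slightly higher number. Compound 3 is estimated at 13000 nM, with a range from 5000 nM to 35000 nM.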

Compound 3, half-maximal inhibitory concentration: > 64000 nM
Compound 3 ended at the assay's limit (the forecaster's own chance of this, stated with the estimate: 10%); middle value at least 4.9-fold (0.69 log units) away from the limit.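

In this assay, compound 3 gives > 64000 nM, which is a limit of the assay and not a number. The change from 2-chlorophenyl to phenyl gives an at least 5.8-fold higher number from compound 1 to compound 3 (0.76 log units; beyond the scatter), so the one chlorine on this aromatic carbon, ortho to a large group, separates a value that can be read from one that lies past the assay's range. The full size of the step stays unknown because only a limit is available for compound 3: the limit of > 64000 nM in this assay, at which 1 of the 3 values shown sits.

Going by these compounds, whether chlorine itself matters here, or whether another group on the same carbon, such as fluoro, methyl or an amine, would serve as well, remains open. Also open, on these data alone, is whether the same swap would have a step of similar size with other groups on the shared core, such as a longer chain in place of the propyl on sulfur.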